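Chain Extension on the Shared Core: From Compound 2 to Compound 3

A few compounds are considered here, and "the series" means these few. Any claim that something is new, unique, unknown or untested is made for them only; others in the source may bear on it.

Measured compounds:
compound 1, `CC[C@H](C)Cn1c(Cc2cc(OC)c(OC)c(OC)c2)nc2c(N)nc(F)nc21`: 66700000 nM
compound 2, `C=CCCn1c(Cc2cc(OC)c(OC)c(OC)c2)nc2c(N)nc(F)nc21`: 102000000 nM

In a functional assay on MCF7 cells (Homo sapiens) for cytotoxicity (a higher number here means that more compound is needed for the effect, a lower number that less compound is needed), compound 1 gives 66700000 nM, and compound 2 gives 102000000 nM. The two values sit within the scatter of each other, the step being a 1.5-fold higher number from compound 1 to compound 2 (0.18 log units; within the scatter). Compound 3, `C=CCCCn1c(Cc2cc(OC)c(OC)c(OC)c2)nc2c(N)nc(F)nc21`, carries the change (allyl in place of vinyl on a saturated chain carbon, two bonds along the chain from an aromatic nitrogen). Going by the values given here, the only measured step that bears on it, an exchange of one short chain for another on the same part of the shared core, was a 1.5-fold higher number from compound 1 to compound 2 (0.18 log units; within the scatter). No shift beyond the scatter is therefore expected in this assay. Compound 3 is expected to give 100000000 nM, between 40000000 nM and 250000000 nM. The estimated step is a 1.0-fold lower number from compound 2 to compound 3 (0.01 log units; within the scatter).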

Compound 3, half-maximal effective concentration: 55600000 nM
Compound 3: middle estimate off by 1.8-fold (0.25 log units), on the high side; the measured number falls inside the stated range.
By their numbers in this assay, from the lowest: compounds 3, 1 and 2 (each within the scatter of the next).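

In this assay, putting allyl in place of vinyl at this position gives a 1.8-fold lower number from compound 2 to compound 3 (0.26 log units; within the scatter), while but-3-en-1-yl in place of sec-butyl on the carbon bound to the aromatic nitrogen gives a 1.2-fold lower number from compound 1 to compound 3 (0.08 log units; within the scatter). Across these three compounds, neither exchange moves the number beyond the scatter, so the branched saturated chain and both unbranched chains ending in a double bond cannot be told apart here. No evidence is available that bears on this result. As far as these compounds go, whether a longer chain, or an amine or a carboxylic acid on this chain, would give a step beyond the scatter remains open.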